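One Ring Swap, Tried Again on a Second Core

The source may report more compounds than this note shows. Statements on the series, on what has been measured and on what is new or still open speak of the compounds shown alone.

Compound 1 `COc1ccc2oc(CSC(=S)N3CCOCC3)cc(=O)c2c1` and compound 3 `COc1ccc2oc(CSC(=S)N3CCCCC3)cc(=O)c2c1` share one core and differ in a single place: piperidin-1-yl in place of morpholin-4-yl on a thiocarbonyl carbon. In a functional assay on SW480 cells (Homo sapiens) for antiproliferative activity, read by MTT assay, with a stated time of 72 h (a lower number here means a stronger inhibitor, a higher number a weaker inhibitor), compound 1 gives 3100 nM, while compound 3 gives 2300 nM, which amounts to a 1.3-fold lower number from compound 1 to compound 3 (0.13 log units; within the scatter). Compound 2 `O=c1c(CSC(=S)N2CCOCC2)coc2cc(Cl)ccc12` carries the same morpholin-4-yl group on another core; the difference between the two cores is not broken down here. In this assay compound 2 gives 6200 nM, the highest of the three numbers. Compound 4 `O=c1c(CSC(=S)N2CCCCC2)coc2cc(Cl)ccc12` stands to compound 2 as compound 3 stands to compound 1, by the same change: piperidin-1-yl in place of morpholin-4-yl on a thiocarbonyl carbon. Resting on the measured 1.3-fold lower number from compound 1 to compound 3 (0.13 log units; within the scatter), a step of similar size is expected for compound 4, namely a 1.3-fold lower number from compound 2 to compound 4 (0.11 log units; within the scatter). Compound 4 is accordingly estimated at 4800 nM, with a likely range from 2500 nM to 9500 nM.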

Compound 4, half-maximal inhibitory concentration: 790 nM
For compound 4 the middle estimate is 6.1-fold (0.78 log units) above the measured one; the measured number lies below the stated range.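

In this assay, piperidin-1-yl in place of morpholin-4-yl on a thiocarbonyl carbon gives a 7.8-fold lower number from compound 2 to compound 4 (0.89 log units; beyond the scatter), a step that stands clear of the scatter, unlike the step on the core of compound 1. The size of this step therefore did not carry from one core to the other: the same change on two cores in this assay, a 1.3-fold lower number (0.13 log units; within the scatter) from compound 1 to compound 3 and a 7.8-fold lower number (0.89 log units; beyond the scatter) from compound 2 to compound 4, 5.8-fold (0.77 log units) apart, beyond the scatter of two such steps. The two pairs show that the outcome of the change depends on the core, but they do not show which feature of the core matters, and they give no rule for any third core.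

Going by these compounds, it remains open whether the larger step on the core of compound 2 is specific to piperidin-1-yl. A piperazin-1-yl group or an open-chain diethylamino group in the same place could settle this.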